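The compounds below may be only part of what the source reports. "The series", "measured", "known", "first", "only" and "open" are said of these compounds alone.

Compound 1, `O=C(/C=C/c1ccccc1)NNC(=O)c1ccccc1O`, gives 900 nM in a functional assay on K562 cells (Homo sapiens) for cytotoxicity, read by MTT assay, with a stated time of 72 h; on this read-out higher numbers stand for weaker inhibition and lower numbers for stronger inhibition.
Compound 2, `COCOc1cc(/C=C/C(=O)OCC(=O)Nc2ccc(OC)cc2)ccc1OCc1ccccc1`, reaches only the limit > 200000 nM in this assay.
Compound 3, `COCOc1cc(/C=C/C(=O)OCC(=O)Nc2ccc(Cl)cc2)ccc1OCc1ccccc1`, likewise reaches only the limit > 200000 nM in this assay.

Compound 3 therefore stands at a limit, not at a number, and it shares that position with compound 2 (the limit of > 200000 nM in this assay, at which 2 of the 3 values shown sit). Among the measured compounds shown here, the one step among the measured compounds that touches compound 3 is the change from compound 2 to compound 3, a step that the two limits leave unreadable from compound 2 to compound 3, which the two limits leave without a readable size or direction. For the measured compounds named here, compound 1, the only compound with a number, shares no single-point change with either of them, so its value says nothing about a step.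

Compound 4, `COCOc1cc(/C=C/C(=O)OCC(=O)NN2CCOCC2)ccc1OCc1ccccc1`, differs from compound 3 by morpholin-4-yl in place of 4-chlorophenyl on an amide-type nitrogen. Going by the values given here, no measured step bears on this change, and the only step at the shared core of compounds 2 and 3 is unreadable. On these data compound 4 is expected to remain at the limit, with a step from compound 3 of a number no higher from compound 3 to compound 4 (the limit leaves the size open) that is expected to show no movement in this assay beyond the scatter. Compound 4 is thus estimated at 200000 nM, within a range of 50000 nM to 200000 nM.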

Compound 4, half-maximal inhibitory concentration: 32400 nM
For compound 4 the middle estimate is 6.2-fold (0.79 log units) above the measured one; the whole stated range lies above it.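

Among the compounds shown here, compound 4 is the first compound on this shared core to give a number rather than a limit in this assay, which shows that the group on the amide-type nitrogen can move the read-out, something the unreadable step between compound 2 and compound 3 could not show. Morpholin-4-yl in place of 4-chlorophenyl gives an at least 6.1-fold lower number from compound 3 to compound 4 (0.79 log units; beyond the scatter), and morpholin-4-yl in place of 4-methoxyphenyl at the same place gives an at least 6.1-fold lower number from compound 2 to compound 4 (0.79 log units; beyond the scatter). Compound 2 and compound 3 both stand at a limit, so each of these steps fixes only a smallest size and the true gap may be wider: the limit of > 200000 nM in this assay, at which 2 of the 4 values shown sit.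

The compounds shown leave open whether the ring oxygen of morpholin-4-yl matters or whether any non-aromatic ring on that nitrogen would do the same, a question that a piperidin-1-yl group in its place would separate. They also leave open how the number would respond to a change elsewhere on the shared core, such as a free hydroxyl in place of the methoxymethyl ether.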